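The source may hold more compounds than are shown below. What is called first, only, known or untested is meant among the compounds shown, and "the series" means these compounds.

Measured compounds:
- compound 1 `O=C(c1c(O)ccc2cc(-c3cccc(O)c3)ccc12)N1CCOCC1`: in an in vitro assay on Sf9 cells for inhibition of 17-beta-hydroxysteroid dehydrogenase type 1 (Homo sapiens), tested at 100 nM (on this read-out higher numbers stand for a stronger effect at the one concentration tested and lower numbers for a weaker effect), compound 1 gives 28%
- compound 2 `Cc1ccc(S(=O)(=O)c2c(O)ccc3cc(-c4cccc(O)c4)ccc23)cc1`: in this assay compound 2 gives "not determined" (no result reported)
- compound 3 `O=C(Nc1ccccc1)c1cc2cc(-c3cccc(O)c3)ccc2cc1O`: in this assay compound 3 gives 17%

Compound 1 holds the higher of the two numbers available in this assay; compound 3 sits lower, a gap beyond the usual scatter, and compound 2 gives no number at all. Compound 4 `O=C(Nc1cccc(O)c1)c1c(O)ccc2cc(-c3cccc(O)c3)ccc12` has not been tested. It differs from compound 1 by (3-hydroxyphenyl)amino in place of morpholin-4-yl on a carbonyl carbon. Within the data shown here, no measured pair shows this exact change, so the size of the step is uncertain. Given that compound 1 reaches 28%, compound 4 is expected to stay near it, with the step of a number 2 percentage points higher from compound 1 to compound 4 (within the scatter) expected to lie within the scatter. Compound 4 is therefore estimated at 30%, with a range from 10% to 55%.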

Compound 4, a percentage reported as inhibition, at one concentration (the size of the read-out at that concentration, not a potency): 21%
Estimate against measurement, compound 4: 9 percentage points above, within the range that was stated.
By their numbers in this assay, from the lowest: compounds 3, 4 and 1 (each within the scatter of the next, the first and the last beyond it).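

On a carbonyl carbon, (3-hydroxyphenyl)amino replaces morpholin-4-yl in this assay with a number 7 percentage points lower from compound 1 to compound 4 (within the scatter), so swapping a non-aromatic ring for an aromatic one leaves the read-out within the scatter. Among these compounds, this is the first step that can be read at this position, since the earlier compounds offered no pair differing in one place. Nothing measured here offers an explanation for this result.

As far as these compounds go, whether dimethylamino or a hydroxyl giving a carboxylic acid on that carbonyl carbon would also stay within the scatter remains open. Compound 3 and compound 4 differ in more than one place, so they give no direct comparison.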